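A few compounds are considered here, and "the series" means these few. Any claim that something is new, unique, unknown or untested is made for them only; others in the source may bear on it.

Measured compounds:
Compound 1 `COC(=O)[C@H](C)NC(=O)c1ccc(Oc2nc3ccccc3nc2C)cc1` gives 32200 nM in a functional assay on HeLa cells (Homo sapiens) for antiproliferative activity, read by MTT assay, with a stated time of 48 h; on this read-out higher numbers stand for weaker inhibition and lower numbers for stronger inhibition.
Compound 2 `Cc1nc2ccccc2nc1Oc1ccc(C(=O)N[C@@H](CC(C)C)C(=O)O)cc1` gives 17300 nM in this assay.

Compound 1 holds the highest of the two numbers shown; the nearest is compound 2, and the step of a 1.9-fold lower number from compound 1 to compound 2 (0.27 log units; within the scatter) lies within the scatter, so the two values cannot be told apart. That single step concerns the group on the amide-type nitrogen, 1-carboxy-3-methylbutyl in place of 1-(methoxycarbonyl)ethyl, and says nothing about the core.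

Compound 3 `COC(=O)[C@H](C)NC(=O)c1ccc(Oc2nc3ccccc3nc2NC(C)(C)C)cc1` keeps the amide side of compound 1 unchanged and alters the core instead: (tert-butyl)amino in place of methyl on an aromatic carbon. The change sits on an aromatic carbon of a six-membered aromatic ring with two nitrogens, part of a fused system of two rings, next to the ring nitrogen and ortho to a large group. Among the compounds with values here, no measured step touches this position, so nothing in the data bears on the size or direction of the effect in this assay; the only measured step lies within the scatter and is at a different place.

Compound 3 is therefore expected to give roughly the number of compound 1, 25000 nM, with a wide range from 5000 nM to 120000 nM, the estimated step being a 1.3-fold lower number from compound 1 to compound 3 (0.11 log units; within the scatter).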

Compound 3, half-maximal inhibitory concentration: 55200 nM
Compound 3: the middle estimate sits 2.2-fold (0.34 log units) below what was measured; the range from low to high includes it.
By their numbers in this assay, from the lowest: compounds 2, 1 and 3 (each within the scatter of the next, the first and the last beyond it).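

Setting (tert-butyl)amino in place of methyl gives the first reading for this aromatic carbon: in this assay the step is a 1.7-fold higher number from compound 1 to compound 3 (0.23 log units; within the scatter), so this exchange cannot be told apart from no change at all. The entering group carries 5 heavy atoms against 1 and brings 1 hydrogen-bond donor and 1 hydrogen-bond acceptor, yet even this exchange on the core leaves the read-out within the scatter, just as the earlier exchange on the amide-type nitrogen did. The data shown hold nothing that would account for this result.

From the compounds shown here alone, it remains open whether other groups on this aromatic carbon, such as a primary amine, a methoxy group or morpholine, would read the same way, and whether (tert-butyl)amino would do so alongside 1-carboxy-3-methylbutyl on the amide-type nitrogen. Equally open, going by these compounds, is whether any exchange at either place can carry the number beyond the scatter of compound 1, which would give this series its first clearly resolved step.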